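The source may hold more compounds than are shown below. What is called first, only, known or untested is meant among the compounds shown, and "the series" means these compounds.

Compound 3 `C=CCOc1ccc2c(Cl)ccnc2c1` gives 2570 nM in a functional assay on HCT-116 cells (Homo sapiens) for cytotoxicity, read by MTT assay, with a stated time of 48 h (on this read-out lower numbers stand for stronger inhibition and higher numbers for weaker inhibition), the highest of the three numbers, yet the steps of a 1.0-fold higher number from compound 1 to compound 3 (0.01 log units; within the scatter) and a 1.1-fold higher number from compound 2 to compound 3 (0.02 log units; within the scatter) are both within the scatter, so compound 1 `CC(C)COc1ccc2c(Cl)ccnc2c1` with 2490 nM and compound 2 `CCCCCCOc1ccc2c(Cl)ccnc2c1` with 2440 nM cannot be told apart from it. Compound 4 `CC(C)Oc1ccc2c(Cl)ccnc2c1` differs from compound 3 by isopropyl in place of allyl on an oxygen on an aromatic ring. For the measured compounds named here, the steps that bear on this, a 1.0-fold lower number from compound 1 to compound 2 (0.01 log units; within the scatter), a 1.0-fold higher number from compound 1 to compound 3 (0.01 log units; within the scatter) and a 1.1-fold higher number from compound 2 to compound 3 (0.02 log units; within the scatter), show that swapping one small chain on that oxygen for another left this assay unchanged each time. The estimated step is therefore a 1.0-fold lower number from compound 3 to compound 4 (0.01 log units; within the scatter), none beyond the scatter. Compound 4 is expected to give 2500 nM, within a range from 1300 nM to 4800 nM.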

Compound 4, half-maximal inhibitory concentration: 2590 nM
The estimate for compound 4 lay 1.0-fold (0.02 log units) below the measured number; measured number inside the range.
By their numbers in this assay, from the lowest: compounds 2, 1, 3 and 4 (each within the scatter of the next).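

In this assay isopropyl directly on the oxygen on an aromatic ring cannot be told apart from allyl (a 1.0-fold higher number from compound 3 to compound 4 (0.00 log units; within the scatter)), hexyl (a 1.1-fold higher number from compound 2 to compound 4 (0.03 log units; within the scatter)) or isobutyl (a 1.0-fold higher number from compound 1 to compound 4 (0.02 log units; within the scatter)). The earlier steps shown here only exchanged groups on a saturated chain carbon bound to that oxygen, so this flat picture now extends to the group on the oxygen itself, and to the loss of allyl's double bond. No measurement shown gives a reason for this sameness. As far as these compounds go, whether an amine or a carboxylic acid on that oxygen's chain would move the number stays open.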